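The compounds below may be only part of what the source reports. "The series", "measured", "known", "first", "only" and "open" are said of these compounds alone.

Series notes. In a physicochemical assay for lipophilicity, measured as octanol-water partition (a higher number here means a more lipophilic compound, a lower number a more polar compound), compound 3 `Cc1c(NCc2nnc(-c3ccncc3)o2)c(=O)n(-c2ccccc2)n1C` gives 0.8, at the low end of the set alongside compound 1 `Cc1c(NCc2nnc(COc3ccccc3)o2)c(=O)n(-c2ccccc2)n1C`, which gives 0.98, the gap being a number 0.18 log units lower from compound 1 to compound 3 (within the scatter); compound 2 `Cc1c(NCc2nnc(-c3ccc(Cl)cc3)o2)c(=O)n(-c2ccccc2)n1C` gives 2.7 and stands well apart, since a number 1.90 log units lower from compound 2 to compound 3 (beyond the scatter). Compound 4 `Cc1c(NCc2nnc(-c3cccs3)o2)c(=O)n(-c2ccccc2)n1C` differs from compound 3 by thiophen-2-yl in place of pyridin-4-yl on an aromatic carbon. The measured step that bears on this exchange is a number 1.90 log units lower from compound 2 to compound 3 (beyond the scatter), the only one in which pyridin-4-yl replaces another aromatic ring; a number 1.72 log units higher from compound 1 to compound 2 (beyond the scatter) was likewise large, while a number 0.18 log units lower from compound 1 to compound 3 (within the scatter) was within the scatter. Among the measured compounds shown here, a step back upward, somewhat smaller than the one from compound 2 to compound 3, is therefore expected, a number 1.20 log units higher from compound 3 to compound 4 (beyond the scatter). Compound 4 is estimated at 2, with a range from 1.5 to 2.5.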

Compound 4, partition coefficient: 1.9
Compound 4: the middle estimate sits 0.10 log units above what was measured; low and high end bracket the measured number.
By their numbers in this assay, from the lowest: compounds 3 and 1 (each within the scatter of the next); then compound 4; then compound 2.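

In this assay, two aromatic rings with one hetero atom each are not interchangeable at this position, as thiophen-2-yl in place of pyridin-4-yl gives (a number 1.10 log units higher from compound 3 to compound 4 (beyond the scatter)). Compound 4 also stands apart from both other groups (a number 0.80 log units lower from compound 2 to compound 4 (beyond the scatter); a number 0.92 log units higher from compound 1 to compound 4 (beyond the scatter)), so this position gives an intermediate value as well as the two extremes seen earlier. No measurement shown accounts for these steps.

On these data alone, how an amine or a carboxylic acid would read at this position remains open. So does the reading for thiophen-3-yl, with the same ring attached through another carbon.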